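A few compounds are considered here, and "the series" means these few. Any claim that something is new, unique, unknown or untested is made for them only; others in the source may bear on it.

Measured compounds:
compound 1, `ClCc1cccc(Cn2cnc3c(Cl)nc(Cl)nc32)c1`, 3460 nM
compound 2, `ClCc1cccc(Cn2cnc3nc(Cl)nc(Cl)c32)c1`, 15100 nM

In a functional assay on UACC-257 cells (Homo sapiens) for cytotoxicity, read by sulforhodamine B assay, with a stated time of 48 h (a lower number here means a stronger inhibitor of growth, a higher number a weaker inhibitor of growth), compound 1 gives 3460 nM, the lower of the two numbers recorded, and compound 2 gives 15100 nM, a higher number that lies beyond the usual scatter. The two compounds are not related by a single change, so nothing more than this ordering can be drawn from them.

The compound still to be measured is compound 3, `Nc1nc(Cl)c2ncn(Cc3cccc(CCl)c3)c2n1`. It differs from compound 1 in one place: amino in place of chloro on an aromatic carbon. The site is the aromatic carbon between two ring nitrogen atoms of the six-membered ring, meta to a chloro group, meta and para to the fused ring.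

Going by the values given here, no measured pair shows what this exchange does in this assay, so the expectation rests on compound 1 alone. A modest weakening is expected, possibly none beyond the scatter, and the step from compound 1 to compound 3 is estimated as a 1.7-fold higher number from compound 1 to compound 3 (0.24 log units; within the scatter). Compound 3 is therefore expected to give about 6000 nM, within a range of 1500 nM to 25000 nM.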

Compound 3, concentration for total growth inhibition: 19500 nM
For compound 3 the middle estimate is 3.3-fold (0.51 log units) below the measured one; measured number inside the range.
By their numbers in this assay, from the lowest: compound 1; then compounds 2 and 3 (each within the scatter of the next).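

Going by these compounds alone, the single change from chloro to amino, on the aromatic carbon between two ring nitrogen atoms, gives in this assay a 5.6-fold higher number from compound 1 to compound 3 (0.75 log units; beyond the scatter) and so provides the first direct reading of this position. The earlier compounds shown here offered only an ordering, whereas this step shows that the position is not indifferent to the exchange: amino in place of chloro weakens growth inhibition beyond the scatter, though only modestly in size. No measurement shown explains this loss, so its origin stays unknown.

The compounds shown leave open whether the loss belongs to amino in particular or follows from any replacement of chloro at this carbon, a question that a methylamino group, a methoxy group or a plain hydrogen at the same place would help to settle. Also open, on these data alone, is whether amino would produce a step of similar size in place of the other chloro group, the one meta to this carbon, since this single pair speaks for one position alone.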